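From an Aromatic Ring to a Saturated One

The source may report more compounds than this note shows. Statements on the series, on what has been measured and on what is new or still open speak of the compounds shown alone.

Among the compounds with values here, compound 2 `COc1cccc(Nc2ncnc3c2ncn3C2O[C@H](CO)[C@@H](O)[C@H]2O)c1` gives 46.8 nM in an assay on isolated protein for binding affinity to adenosine receptor A1 (Rattus norvegicus) (a lower number here means a stronger inhibitor, a higher number a weaker inhibitor), the higher of the two numbers measured so far. Compound 1 `Cc1ccccc1Nc1ncnc2c1ncn2C1O[C@H](CO)[C@@H](O)[C@H]1O` gives 8.91 nM in this assay, and the change between them amounts to a 5.3-fold higher number from compound 1 to compound 2 (0.72 log units; beyond the scatter). Compound 3 `OC[C@H]1OC(n2cnc3c(NCC4CCCCC4)ncnc32)[C@H](O)[C@@H]1O` differs from compound 2 by cyclohexylmethyl in place of 3-methoxyphenyl on a nitrogen on an aromatic ring. That measured step swapped one aromatic ring for another, so it bears only loosely on an exchange for a non-aromatic ring, and the direction is uncertain. Compound 3 is nevertheless expected to give about 15 nM, within 3 nM to 80 nM, an expected step of a 3.1-fold lower number from compound 2 to compound 3 (0.49 log units; beyond the scatter).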

Compound 3, half-maximal inhibitory concentration: 39.8 nM
Beside the measured number, compound 3's estimate is 2.7-fold (0.42 log units) below it, within the range that was stated.
By their numbers in this assay, from the lowest: compound 1; then compounds 3 and 2 (each within the scatter of the next).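

Replacing 3-methoxyphenyl with cyclohexylmethyl on this nitrogen removes both the aromatic ring and the methoxy oxygen, yet in this assay the two compounds cannot be told apart (a 1.2-fold lower number from compound 2 to compound 3 (0.07 log units; within the scatter)). An aromatic ring is therefore not required here for binding in the range of compound 2, although compound 1 remains ahead of the saturated ring (a 4.5-fold higher number from compound 1 to compound 3 (0.65 log units; beyond the scatter)). No available evidence explains this result. An open-chain hexyl group would test whether any ring is needed at all. Going by these compounds, whether an amine on the cyclohexane ring would shift the number also remains open.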